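Peptide Chain Caps at the Ceiling of Stability

The source may report more compounds than this note shows. Statements on the series, on what has been measured and on what is new or still open speak of the compounds shown alone.

Of the compounds shown here, two built on the same peptide-like core have been measured in an ADME assay for metabolic stability, in the presence of a further agent that is not named here; a higher number here means that the compound lasts longer, a lower number that the compound disappears faster. In this assay compound 1 `CCOC(=O)/C=C/[C@H](CC(C)C)NC(=O)[C@H](CC(C)C)NC(=O)[C@H](CC(C)C)NC(=O)OCc1ccccc1` reaches the top of what the measurement reports, > 6 h, which is a limit rather than a number. Compound 2 `CCOC(=O)/C=C/[C@H](CC(C)C)NC(=O)[C@H](CC(C)C)NC(=O)[C@H](CC(C)C)NC(=O)C1=CCCNC1` likewise stops at a limit, > 6 h. Within the data shown here, the single step between them, a step that the two limits leave unreadable from compound 1 to compound 2, cannot be read in size or direction because of the limit of > 6 h in this assay, at which 2 of the 2 values shown sit. Compound 2 therefore stands at the ceiling of this assay, and the numbers give no order between it and compound 1.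

Compound 3 `CCOC(=O)/C=C/[C@H](CC(C)C)NC(=O)[C@H](CC(C)C)NC(=O)[C@H](CC(C)C)NC(=O)c1cccc(O)c1C` has not yet been measured. It differs from compound 2 in one place: a group of 8 heavy atoms (7 carbon, 1 oxygen; one six-membered aromatic ring of carbon only) in place of a group of 6 heavy atoms (5 carbon, 1 nitrogen; one six-membered non-aromatic ring with 1 hetero atom), on a carbonyl carbon. Among the measured compounds shown here, the only measured step that touches this carbonyl carbon is the unreadable one, so it offers neither a size nor a direction to lean on. With both measured compounds at the limit, the expected step, a number no higher from compound 2 to compound 3 (the limit leaves the size open), amounts to no change beyond the scatter. Compound 3 is therefore estimated to sit at 6 h, within a range from 2.5 h to 12 h, most likely reported again only as a limit.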

Compound 3, half-life: > 6 h
Compound 3 was reported as a limit; the forecaster's own chance of this, stated with the estimate: 70%; the middle value lies on the limit itself.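

In this assay compound 3 is also reported only as a limit, so its steps from compound 1 and compound 2 cannot be read in size or direction, because all three compounds stop at the same ceiling: (the limit of > 6 h in this assay, at which 3 of the 3 values shown sit). The compounds shown leave open how long each actually lasts, and whether the group on the carbonyl carbon matters for this read-out at all.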